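The source may hold more compounds than are shown below. What is called first, only, known or untested is meant among the compounds shown, and "the series" means these compounds.

Measured so far in an ADME assay on microsomes from liver (Homo sapiens) for metabolic stability, using NADPH, with a stated time of 40 min, tested at 2 uM; a lower number here means that the compound disappears faster, a higher number that the compound lasts longer:
- compound 1 `Fc1cc(Cl)c2[nH]cc(-c3ccc4ccccc4n3)c2c1` gives 0.383 h
- compound 2 `Cc1cc(F)cc2c(-c3ccc4ccccc4n3)c[nH]c12` gives 1.1 h

Compound 2 (1.1 h) holds the higher of the two numbers. The next compound, compound 3 `Cc1cc(C)c2[nH]cc(-c3ccc4ccccc4n3)c2c1`, has methyl in place of fluoro on an aromatic carbon. Among the compounds with values here, one measured step bears on this change (a 2.9-fold higher number from compound 1 to compound 2 (0.46 log units; beyond the scatter)). That step also brought in methyl, but it replaced chloro rather than fluoro, so it is only a loose guide. A smaller step in this assay is therefore expected, with an upward direction tentative and possibly none beyond the scatter. The expected step is small (a 1.1-fold higher number from compound 2 to compound 3 (0.04 log units; within the scatter)). Compound 3 is estimated at 1.2 h (expected range 0.5 h to 2.8 h).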

Compound 3, half-life: 1.57 h
Estimate against measurement, compound 3: 1.3-fold (0.12 log units) below, and the stated range covers the measured number.
By their numbers in this assay, from the lowest: compound 1; then compounds 2 and 3 (each within the scatter of the next).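

In this assay, methyl in place of fluoro on this aromatic carbon gives a 1.4-fold higher number from compound 2 to compound 3 (0.15 log units; within the scatter), so the half-life does not separate these two groups at this position. Within the data shown here, the one earlier step, a 2.9-fold higher number from compound 1 to compound 2 (0.46 log units; beyond the scatter), also brought in methyl, but it replaced chloro in another place on the ring and lies beyond the scatter. Nothing at hand accounts for this difference between the two steps.

As far as these compounds go, whether an amine or a methoxy group on this aromatic carbon would move the half-life beyond the scatter remains open. So does whether any group here can match the size of the step seen on replacing chloro.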